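A few compounds are considered here, and "the series" means these few. Any claim that something is new, unique, unknown or untested is made for them only; others in the source may bear on it.

Compound 1 `COc1cc(/C=C(/SCc2ccc(Br)cc2)C(=O)c2ccc(C(=O)O)cc2)ccc1F`: 1000 nM
Compound 2 `O=C(/C(=C\c1ccc(Br)cc1)Sc1ccccc1Br)c1ccc(Br)cc1`: 1000 nM
Compound 3 `CN(C)c1ccc(/C=C(\C(=O)c2ccc(Br)cc2)S(=O)(=O)Cc2ccc(F)cc2)cc1`: 50000 nM

In a functional assay on DU-145 cells (Homo sapiens) for inhibition, read by trypan blue exclusion, with a stated time of 96 h (on this read-out lower numbers stand for stronger inhibition of growth and higher numbers for weaker inhibition of growth), compound 1 and compound 2 lie within the scatter of each other and together hold the lowest number of the three, well clear of compound 3. Compound 4 `CN1CCN(/C=C(/SCc2ccc(Br)cc2)C(=O)c2ccc(C(=O)O)cc2)CC1[N+](=O)[O-]` carries 4-methyl-3-nitropiperazin-1-yl in place of 4-fluoro-3-methoxyphenyl on a double-bonded chain carbon bound to a double-bonded chain carbon. For the measured compounds named here, no measured pair isolates this exchange. Going by the values given here, the only guide is the spread from compound 1 at 1000 nM to compound 3 at 50000 nM. A moderate rise in this assay, toward weaker inhibition of growth, is expected, as the estimated step of a 5.0-fold higher number from compound 1 to compound 4 (0.70 log units; beyond the scatter). For compound 4 the estimate is 5000 nM, with an expected range of 1000 nM to 25000 nM.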

Compound 4, concentration for 50% growth inhibition: 10000 nM
Compound 4: the middle estimate sits 2.0-fold (0.30 log units) below what was measured; low and high end bracket the measured number.
By their numbers in this assay, from the lowest: compounds 1 and 2 (each within the scatter of the next); then compound 4; then compound 3.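

Earlier compounds carry only substituted phenyl rings on the double-bonded chain carbon, so compound 4 is the first shown with a non-aromatic ring there. In this assay, the exchange of 4-fluoro-3-methoxyphenyl for 4-methyl-3-nitropiperazin-1-yl gives a 10-fold higher number from compound 1 to compound 4 (1.00 log units; beyond the scatter), so this place responds to the change, with weaker inhibition of growth. No measurement given here explains this step.

The compounds shown leave open whether the ring itself or its nitro group carries the loss. A plain piperazin-1-yl or a 3-nitrophenyl group at this place would separate the two.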